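Epimer of a Fluorophenylpiperazine Camphor-Derived Alcohol

A few compounds are considered here, and "the series" means these few. Any claim that something is new, unique, unknown or untested is made for them only; others in the source may bear on it.

This account follows compound 1 `CC1(C)[C@@H]2CC[C@@]1([C@H](O)CN1CCN(c3ccccc3F)CC1)C(=O)C2` to its epimer compound 4 `CC1(C)[C@@H]2CC[C@@]1([C@@H](O)CN1CCN(c3ccccc3F)CC1)C(=O)C2`. In an ADME assay on HEK-293T cells (Homo sapiens) for cytotoxicity, read by MTT assay, with a stated time of 72 h (a lower number here means a stronger inhibitor, a higher number a weaker inhibitor), compound 1 gives 120000 nM. Its 4-fluorophenyl analogue, compound 3 `CC1(C)[C@@H]2CC[C@@]1([C@H](O)CN1CCN(c3ccc(F)cc3)CC1)C(=O)C2`, gives 65100 nM in this assay, and a 1.8-fold lower number from compound 1 to compound 3 (0.27 log units; within the scatter), so the two numbers are not set apart from each other. The unsubstituted phenyl analogue, compound 2 `CC1(C)[C@@H]2CC[C@@]1([C@H](O)CN1CCN(c3ccccc3)CC1)C(=O)C2`, has no result in this assay, "not determined" (no result reported).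

Compound 4 differs from compound 1 as follows: the two compounds have the same atoms and bonds and differ only in configuration as drawn: 1 of 3 stereo elements differ; a stereocentre at a saturated chain carbon is drawn S in compound 1 and R in compound 4. Among the measured pairs, no step involves a change of configuration; the only step known moves a fluorine around the aromatic ring and stays within the scatter. Nothing in the data therefore points to a shift in either direction, and compound 4 is expected to sit near compound 1, with no change at the digits printed from compound 1 to compound 4 (within the scatter) as the estimated step. Compound 4 is thus estimated at 120000 nM in this assay, within a range of 50000 nM to 300000 nM.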

Compound 4, half-maximal inhibitory concentration: 129000 nM
Beside the measured number, compound 4's estimate is 1.1-fold (0.03 log units) below it; the measured number falls inside the stated range.
By their numbers in this assay, from the lowest: compounds 3, 1 and 4 (each within the scatter of the next).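

Among these compounds, until this point the only step that could be read moved a fluorine around the aromatic ring; this is the first to change configuration, at the saturated chain carbon, and in this assay it gives a 1.1-fold higher number from compound 1 to compound 4 (0.03 log units; within the scatter). With the 2-fluorophenyl group in place, drawing this stereocentre R rather than S therefore does not set the two numbers apart. The comparison bears on configuration alone, and nothing else in the structure enters into this step: the fact that compounds 1 and 4 differ only in the configuration as drawn.

From the compounds shown here alone, whether the same holds with the 4-fluorophenyl group of compound 3 or the unsubstituted phenyl group of compound 2 stays open. The compounds shown also leave unanswered how the number would respond if a chlorine took the place of the fluorine, or an amine the place of the hydroxyl group.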